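Predicting stability after a sulfonyl swap on the des-chloro core

The source may report more compounds than this note shows. Statements on the series, on what has been measured and on what is new or still open speak of the compounds shown alone.

Measured so far:
compound 1 `C=CC(=O)Nc1cc(Nc2ncc(Cl)c(Nc3ccccc3S(=O)(=O)C(C)C)n2)c(OC)cc1N(C)CCN(C)C` 11%
compound 2 `C=CC(=O)Nc1cc(Nc2ncc(Cl)c(Nc3ccccc3S(=O)(=O)N(C)C)n2)c(OC)cc1N(C)CCN(C)C` 13%
compound 3 `C=CC(=O)Nc1cc(Nc2nccc(Nc3ccccc3S(=O)(=O)N(C)C)n2)c(OC)cc1N(C)CCN(C)C` 6%

All three numbers come from an ADME assay on microsomes from liver (Rattus norvegicus) for metabolic stability, read by LC-MS, using NADPH, with a stated time of 30 min, tested at 1 uM; on this read-out lower numbers stand for a less stable compound and higher numbers for a more stable compound. Compound 1 and compound 2 share one core and differ only in one place: isopropyl in place of dimethylamino on a sulfonyl sulfur. That step was small, a number 2 percentage points lower from compound 2 to compound 1 (within the scatter). Compound 3 carries a different core, and how the two cores differ is given by hydrogen in place of chloro on an aromatic carbon; that change also moved the number only a little, a number 7 percentage points lower from compound 2 to compound 3 (within the scatter). All three values sit close together at the low end of the scale.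

Compound 4 `C=CC(=O)Nc1cc(Nc2nccc(Nc3ccccc3S(=O)(=O)C(C)C)n2)c(OC)cc1N(C)CCN(C)C` has not yet been measured in this assay. It stands to compound 3 as compound 1 stands to compound 2: isopropyl in place of dimethylamino on a sulfonyl sulfur. The place of the change is described in the same words in both pairs, so the change is the same one, made on the other core. Since the earlier step was small, the step from compound 3 to compound 4 is expected to be similar, a number 1 percentage points lower from compound 3 to compound 4 (within the scatter), and because compound 3 gives 6% the value of compound 4 is estimated at 5%, most likely between 1% and 12%.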

Compound 4, percent of the compound remaining: 22%
Compound 4: the middle estimate sits 17 percentage points below what was measured, outside the stated range (above it).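

Isopropyl in place of dimethylamino on a sulfonyl sulfur gave a number 16 percentage points higher from compound 3 to compound 4 (beyond the scatter) in this assay, so this change cannot be assumed to have the same effect on both cores: the same change on two cores in this assay, a number 2 percentage points lower (within the scatter) from compound 2 to compound 1 and a number 16 percentage points higher (beyond the scatter) from compound 3 to compound 4, 18 percentage points apart, beyond the scatter of two such steps

Read the other way, hydrogen in place of chloro on an aromatic carbon gave a number 11 percentage points higher from compound 1 to compound 4 (beyond the scatter), so the result of that change also depends on which group sits on the sulfonyl sulfur: the same change on two cores in this assay, a number 7 percentage points lower (within the scatter) from compound 2 to compound 3 and a number 11 percentage points higher (beyond the scatter) from compound 1 to compound 4, 18 percentage points apart, beyond the scatter of two such steps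

This shows that the effects of the two changes do not simply add up across these four compounds, but it rests on this single set and does not show why they fail to add up.

Open, going by these compounds, is whether the same dependence appears with other groups on the sulfonyl sulfur, such as ethyl, cyclopropyl or morpholine, or with fluoro or methyl in place of chloro. Also open, on these data alone, is which part of these molecules is attacked in the liver microsomes.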